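Nitro Added Beside Chloro: Cytotoxicity on Macrophage Cells

A few compounds are considered here, and "the series" means these few. Any claim that something is new, unique, unknown or untested is made for them only; others in the source may bear on it.

Measured compounds:
compound 1 `CCS(=O)(=O)Nc1ccc(NC(=O)c2ccc(Cl)c([N+](=O)[O-])c2)cc1OC`: 5660 nM
compound 2 `CS(=O)(=O)Nc1ccc(NC(=O)c2ccc(Cl)c([N+](=O)[O-])c2)cc1Cl`: 43600 nM
compound 3 `CCS(=O)(=O)Nc1ccc(NC(=O)c2ccc(Cl)cc2)cc1Cl`: > 250000 nM

In an ADME assay on RAW264.7 cells (Mus musculus) for cytotoxicity, read by MTT assay, with a stated time of 48 h (a lower number here means a stronger inhibitor, a higher number a weaker inhibitor), compound 1 gives 5660 nM and compound 2 gives 43600 nM. For compound 3 this assay reports only a limit, > 250000 nM, so its value is known merely as lying at the limit of > 250000 nM in this assay, at which 1 of the 3 values shown sits; no number places it among the others. Compound 4 `CCS(=O)(=O)Nc1ccc(NC(=O)c2ccc(Cl)c([N+](=O)[O-])c2)cc1Cl` differs from compound 3 by nitro in place of hydrogen on an aromatic carbon, ortho to a chloro group and meta to a large group. Compound 1 and compound 2 both carry that nitro group and give numbers inside the range of this assay, so a step toward a lower number is expected. For compound 4 the estimated step is an at least 12-fold lower number from compound 3 to compound 4 (1.09 log units; beyond the scatter), giving an expected value of 20000 nM, with a range from 5000 nM to 100000 nM.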

Compound 4, half-maximal inhibitory concentration: 125000 nM
For compound 4 the middle estimate is 6.3-fold (0.80 log units) below the measured one; measured number above the stated range.
By their numbers in this assay, from the lowest: compound 1; then compound 2; then compound 4. At a limit, above all of these: compound 3.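

With nitro on this aromatic carbon, ortho to a chloro group, this assay shows an at least 2.0-fold lower number from compound 3 to compound 4 (0.30 log units; that floor lies within the scatter), but the true size of this change stays open, since compound 3 is only a limit: the limit of > 250000 nM in this assay, at which 1 of the 4 values shown sits.

Among the compounds carrying nitro, other places also matter, with a 2.9-fold higher number from compound 2 to compound 4 (0.46 log units; beyond the scatter) for methyl in place of hydrogen on a saturated chain carbon bound to a sulfonyl sulfur, and a 22-fold higher number from compound 1 to compound 4 (1.34 log units; beyond the scatter) for chloro in place of methoxy on an aromatic carbon.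

The compounds shown leave open how an amine or a nitrile on this same carbon would compare with nitro.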